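A few compounds are considered here, and "the series" means these few. Any claim that something is new, unique, unknown or untested is made for them only; others in the source may bear on it.

Working notes on compound 1 `COc1cc(/C=N/NC(=O)c2nn(-c3ccc(F)c(Cl)c3)c(-c3ccc(Cl)cc3)c2C)ccc1O` alongside compound 2 `COc1cc(/C=N/NC(=O)c2nn(-c3ccnc4cc(Cl)ccc34)c(-c3ccc(Cl)cc3)c2C)ccc1O` and compound 3 `COc1cc(/C=N/NC(=O)c2nn(-c3ccc(C(F)(F)F)cc3)c(-c3ccc(Cl)cc3)c2C)ccc1O`. In a physicochemical assay (on this read-out lower numbers stand for an effect already at smaller amounts and higher numbers for an effect only at larger amounts of compound), compound 1 gives 3560000 nM as its value, compound 2 gives 4590000 nM as its value and compound 3 gives 2340000 nM as its value. Compound 1 therefore cannot be separated from either of the other two.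

The next compound is compound 4 `COc1cc(/C=N/NC(=O)c2nn(-c3ccc(F)c(Cl)c3)c(-c3ccc(F)cc3)c2C)ccc1O` and its difference from compound 1 is fluoro in place of chloro on an aromatic carbon in short: fluoro in place of chloro on an aromatic carbon, para to a large group. For the measured compounds named here, no measured step covers this carbon. All three concern the group on an aromatic nitrogen and offer only indirect guidance: a 1.3-fold higher number from compound 1 to compound 2 (0.11 log units; within the scatter) and a 1.5-fold lower number from compound 1 to compound 3 (0.18 log units; within the scatter) and a 2.0-fold lower number from compound 2 to compound 3 (0.29 log units; within the scatter) all lie within the scatter. Even a 2.0-fold lower number from compound 2 to compound 3 (0.29 log units; within the scatter) stays inside it, so for this exchange of one halogen no step beyond the scatter is expected in either direction in this assay on this evidence. The estimated step is a 1.0-fold lower number from compound 1 to compound 4 (0.02 log units; within the scatter) and it is expected to stay within the scatter. Compound 4 is estimated at 3400000 nM with an expected range from 2000000 nM to 5600000 nM for repeated measurements.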

Compound 4, half-maximal effective concentration: 6920000 nM
Beside the measured number, compound 4's estimate is 2.0-fold (0.31 log units) below it; the whole stated range lies below it.
By their numbers in this assay, from the lowest: compounds 3, 1, 2 and 4 (each within the scatter of the next, the first and the last beyond it).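

For the compounds shown here, this is the first reading on the aromatic carbon para to a large group, as the earlier steps all concerned the group on an aromatic nitrogen. In this assay, the change from 4-chlorophenyl to 4-fluorophenyl gives a 1.9-fold higher number from compound 1 to compound 4 (0.29 log units; within the scatter), so this exchange of one halogen for another cannot be separated from repeat-measurement scatter and shows no effect of the halogen at this position. Nothing on hand explains the size of this step.

As far as these compounds go, whether an amine, a carboxylic acid or a methoxy group on this carbon would move the number beyond the scatter stays open. Also open, from the compounds shown here alone, is whether the same exchange would give a comparable step with 7-chloroquinolin-4-yl or 4-(trifluoromethyl)phenyl on the aromatic nitrogen.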